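A Thiophene Swap on the Strongest Compound So Far

This account rests on a few compounds, and the source may have more. Where it says the series, first, only, none or still open, it means among the compounds named here.

Compound 1 (`Oc1cccc(-c2cc(-c3ccccc3)cc(-c3ccccc3)n2)c1`) gives 18000 nM
Compound 2 (`Oc1cccc(-c2cc(-c3ccccc3)cc(-c3cccs3)n2)c1`) gives 18900 nM
Compound 3 (`Oc1ccc(-c2cc(-c3ccccc3)cc(-c3ccccc3)n2)cc1`) gives 3000 nM

All three values come from a functional assay on DU-145 cells (Homo sapiens) for cytotoxicity, read by ELISA, with a stated time of 2 days (a higher number here means a weaker inhibitor, a lower number a stronger inhibitor), and compound 3 has the lowest number of the three, with both compound 1 and compound 2 well above it.

Compound 4 (`Oc1ccc(-c2cc(-c3ccccc3)cc(-c3cccs3)n2)cc1`) keeps the 4-hydroxyphenyl group of compound 3 and changes one thing: thiophen-2-yl in place of phenyl on an aromatic carbon, next to the ring nitrogen (thiophen-2-yl in place of phenyl on an aromatic carbon). The same swap has been measured once, on a compound with a 3-hydroxyphenyl group instead, and it gave a 1.1-fold higher number from compound 1 to compound 2 (0.02 log units; within the scatter) as its step. That is the closest guide available. The other measured step, a 6.0-fold lower number from compound 1 to compound 3 (0.78 log units; beyond the scatter), exchanges 3-hydroxyphenyl for 4-hydroxyphenyl and shows that the two hydroxyphenyl groups do not give the same number. The data do not show whether the swap behaves alike with each of them, so the guide is a single, imperfect precedent.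

In this assay no step beyond the scatter is therefore expected, in either direction. The expected step is a 1.1-fold higher number from compound 3 to compound 4 (0.03 log units; within the scatter) and it rests on that one precedent. For compound 4 the estimated value is 3200 nM with 1300 nM to 8000 nM as the expected range.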

Compound 4, half-maximal inhibitory concentration: 3700 nM
The estimate for compound 4 lay 1.2-fold (0.06 log units) below the measured number; measured number inside the range.
By their numbers in this assay, from the lowest: compounds 3 and 4 (each within the scatter of the next); then compounds 1 and 2 (each within the scatter of the next).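

With the 4-hydroxyphenyl group in place, thiophen-2-yl next to the ring nitrogen again leaves the number within the scatter in this assay, with a 1.2-fold higher number from compound 3 to compound 4 (0.09 log units; within the scatter), so phenyl and thiophen-2-yl at this position cannot be told apart on either hydroxyphenyl core: the same change on two cores in this assay, a 1.1-fold higher number (0.02 log units; within the scatter) from compound 1 to compound 2 and a 1.2-fold higher number (0.09 log units; within the scatter) from compound 3 to compound 4, 1.2-fold (0.07 log units) apart, within the scatter of two such steps

The reverse comparison adds a second result, since 4-hydroxyphenyl in place of 3-hydroxyphenyl still gives a step beyond the scatter when thiophen-2-yl is present, with a 5.1-fold lower number from compound 2 to compound 4 (0.71 log units; beyond the scatter), and its size matches the step seen with phenyl: the same change on two cores in this assay, a 6.0-fold lower number (0.78 log units; beyond the scatter) from compound 1 to compound 3 and a 5.1-fold lower number (0.71 log units; beyond the scatter) from compound 2 to compound 4, 1.2-fold (0.07 log units) apart, within the scatter of two such steps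

Across these four compounds, the two changes therefore read as independent of each other, with the hydroxyphenyl group separating the numbers and the ring next to the nitrogen leaving them within the scatter, and no compound here goes against this.

How an amine, a carboxylic acid or a longer chain at this position would read in this assay stays open, since phenyl and thiophen-2-yl are the only groups shown there. Also open, going by these compounds, is whether the hydroxyl group itself matters, as every compound here carries one on its phenyl ring, and a methoxy group in its place would be one way to ask.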